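The compounds below may be only part of what the source reports. "The series", "measured", "known", "first", "only" and "open" are said of these compounds alone.

Compound 1 `Cc1cccc(Cn2cc(COc3ccc4c(=O)ccoc4c3)nn2)c1` gives 11700 nM in a functional assay on SW480 cells (Homo sapiens) for cytotoxicity, read by MTT assay, with a stated time of 48 h; a lower number here means a stronger inhibitor, a higher number a weaker inhibitor.
Compound 2 `O=c1ccoc2cc(OCc3cn(Cc4ccccc4F)nn3)ccc12` gives 11400 nM in this assay.
Compound 3 `CC(C)(C)c1ccc(Cn2cc(COc3ccc4c(=O)ccoc4c3)nn2)cc1` gives 28800 nM in this assay.

Compound 3 holds the highest number of the three measured in this assay; compound 1 sits a step below it that is beyond the scatter, and compound 2 sits a little further below. The change toward compound 4 `COc1ccc(Cn2cc(COc3ccc4c(=O)ccoc4c3)nn2)cc1` is methoxy in place of tert-butyl on an aromatic carbon. Going by the values given here, no measured pair covers this exchange directly. Among the compounds with values here, the only measured single step, a 1.0-fold lower number from compound 1 to compound 2 (0.01 log units; within the scatter), alters the substituent on the same ring and leaves the number within the scatter, so that step says only that a small group on this ring can be swapped without a clear effect in this assay. What compound 3 adds is that the tert-butyl analogue lies clearly above both smaller-substituted analogues. Taking methoxy as closer in count to those smaller groups than to tert-butyl, the expected step is a 1.9-fold lower number from compound 3 to compound 4 (0.28 log units; within the scatter), downward in number, because compound 3 stands at 28800 nM whereas compound 1 stands at 11700 nM. Compound 4 is estimated at 15000 nM, with a range from 7000 nM to 33000 nM.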

Compound 4, half-maximal inhibitory concentration: 20400 nM
Estimate against measurement, compound 4: 1.4-fold (0.13 log units) below; the range from low to high includes it.
By their numbers in this assay, from the lowest: compounds 2, 1, 4 and 3 (each within the scatter of the next, the first and the last beyond it).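

Replacing tert-butyl with methoxy on this aromatic carbon, para to a large group, gives a 1.4-fold lower number from compound 3 to compound 4 (0.15 log units; within the scatter) in this assay, so this exchange at this position does not produce a separable change in the number. Compound 4 also cannot be separated from the other two analogues, with a 1.8-fold higher number from compound 2 to compound 4 (0.25 log units; within the scatter) and a 1.7-fold higher number from compound 1 to compound 4 (0.24 log units; within the scatter) both lying within the scatter, and it therefore links compound 3 to compounds 1 and 2 even though compound 3 stands beyond the scatter of each of those two. No measurement shown here offers an explanation for these numbers.

From the compounds shown here alone, all of the substituents compared so far are uncharged, and it remains open whether an amine, a carboxylic acid or a longer alkoxy chain on this ring would stay within the same narrow span of values. Compounds 1, 2 and 4 also change both the group and its place on the ring, so the contribution of each cannot be separated until one group is compared at more than one place.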